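Aryl swap at the hydrazone carbon: expected cytotoxicity of compound 4

The compounds below may be only part of what the source reports. "The series", "measured", "known", "first", "only" and "open" are said of these compounds alone.

Measured so far in an ADME assay on WI-38 cells (Homo sapiens) for cytotoxicity, read by MTT assay, with a stated time of 72 h; a higher number here means a weaker inhibitor, a lower number a stronger inhibitor:
- compound 1 `COc1ccc(/C=N/NC(=O)Nc2ccc(Oc3ccnc(-c4nncn4CCN(C)C)c3)c(F)c2)c(OC)c1`: 6630 nM
- compound 3 `CN(C)CCn1cnnc1-c1cc(Oc2ccc(NC(=O)N/N=C/c3ccc(F)cc3)cc2F)ccn1`: 3980 nM
- compound 2 `CN(C)CCn1cnnc1-c1cc(Oc2ccc(NC(=O)N/N=C/c3ccccc3)cc2F)ccn1`: "not determined" (no result reported)

Going by the values given here, compound 1 gives the highest of the two numbers in this assay; its nearest neighbour is compound 3, and the only single-point step, a 1.7-fold lower number from compound 1 to compound 3 (0.22 log units; within the scatter), lies within the scatter. Compound 4 `CN(C)CCn1cnnc1-c1cc(Oc2ccc(NC(=O)N/N=C/c3cccc(Cl)c3Cl)cc2F)ccn1` differs from compound 1 by 2,3-dichlorophenyl in place of 2,4-dimethoxyphenyl on a carbon with a double bond to nitrogen. Among the compounds with values here, the one step that bears on this change, a 1.7-fold lower number from compound 1 to compound 3 (0.22 log units; within the scatter), also exchanged the aryl group on that carbon and moved the number by less than the scatter, so no step beyond the scatter is expected here, in either direction. Compound 4 is therefore estimated at 4500 nM in this assay, between 1500 nM and 13000 nM, a step of a 1.5-fold lower number from compound 1 to compound 4 (0.17 log units; within the scatter).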

Compound 4, half-maximal inhibitory concentration: 6130 nM
Estimate against measurement, compound 4: 1.4-fold (0.13 log units) below; low and high end bracket the measured number.
By their numbers in this assay, from the lowest: compounds 3, 4 and 1 (each within the scatter of the next).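

In this assay the steps of a 1.1-fold lower number from compound 1 to compound 4 (0.03 log units; within the scatter) and a 1.5-fold higher number from compound 3 to compound 4 (0.19 log units; within the scatter) both lie within the scatter. On the carbon with a double bond to nitrogen, a chlorine-bearing aryl group thus gives a number that cannot be told apart from those of the methoxy-bearing and fluorine-bearing aryl groups of compound 1 and compound 3. Nothing available explains why these three aryl groups read alike. Still open, from the compounds shown here alone, is whether an aryl group carrying an amine or a carboxylic acid would move the number beyond the scatter. Also open, going by these compounds, is what a plain alkyl chain on that carbon would do.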